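Swapping the Amide Aryl Group: Toward Compound 4

The source may hold more compounds than are shown below. What is called first, only, known or untested is meant among the compounds shown, and "the series" means these compounds.

Compound 1, `O=C(CSc1nc(Nc2ccccc2)c2ccccc2n1)Nc1ccccc1Cl`: 9610 nM in a functional assay on NCI-H1975 cells (Homo sapiens) for inhibition, read by MTT assay, with a stated time of 72 h; a lower number here means a stronger inhibitor, a higher number a weaker inhibitor
Compound 2, `CCc1cccc(NC(=O)CSc2nc(Nc3ccccc3)c3ccccc3n2)c1`: 12000 nM
Compound 3, `COc1cccc(NC(=O)CSc2nc(Nc3ccccc3)c3ccccc3n2)c1`: 19400 nM

Compound 3 gives the highest of the three numbers in this assay; its gap to compound 2 is within the scatter, while a 2.0-fold higher number from compound 1 to compound 3 (0.31 log units; beyond the scatter) lies beyond it. Compound 4, `O=C(CSc1nc(Nc2ccccc2)c2ccccc2n1)Nc1ccc(Cl)cc1`, differs from compound 3 by 4-chlorophenyl in place of 3-methoxyphenyl on an amide-type nitrogen. Among the compounds with values here, no measured step ends in a 4-chlorophenyl, but compound 1, which also carries a chlorophenyl on that nitrogen, gives 9610 nM, and a 1.6-fold higher number from compound 2 to compound 3 (0.21 log units; within the scatter) shows that exchanging groups on this ring moves the number only modestly. A modest step toward a lower number is therefore expected, a 1.8-fold lower number from compound 3 to compound 4 (0.25 log units; within the scatter). Compound 4 is estimated at 11000 nM, with a range from 4500 nM to 28000 nM.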

Compound 4, half-maximal inhibitory concentration: 8040 nM
Estimate against measurement, compound 4: 1.4-fold (0.14 log units) above; low and high end bracket the measured number.
By their numbers in this assay, from the lowest: compounds 4, 1, 2 and 3 (each within the scatter of the next, the first and the last beyond it).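

In this assay, the 3-methoxyphenyl group now stands apart from both chlorophenyl groups on the amide-type nitrogen, not only from 2-chlorophenyl, with a 2.4-fold lower number from compound 3 to compound 4 (0.38 log units; beyond the scatter). The 2-chlorophenyl and 4-chlorophenyl groups cannot be told apart, at a 1.2-fold lower number from compound 1 to compound 4 (0.08 log units; within the scatter), and 3-ethylphenyl likewise stays level with 4-chlorophenyl, at a 1.5-fold lower number from compound 2 to compound 4 (0.17 log units; within the scatter). Nothing available here accounts for these differences. The compounds shown leave open whether a ring carrying an amine or a carboxylic acid would leave this narrow band of numbers. They also leave open what a longer chain in place of the aryl group would do.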